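A trimethoxyphenyl exchange on a weak growth inhibitor

The source may report more compounds than this note shows. Statements on the series, on what has been measured and on what is new or still open speak of the compounds shown alone.

Measured in a functional assay on UO-31 cells (Homo sapiens) for inhibition (a lower number here means a stronger inhibitor of growth, a higher number a weaker inhibitor of growth), as follows:
compound 1 `COc1cc(/C=C/C(=O)c2cccc(-n3cc(-c4ccc(Cl)cc4)[nH]c3=O)c2)cc(OC)c1OC` at 7030 nM
compound 2 `O=C(/C=C/c1cccc(O)c1)c1cccc(-n2cc(-c3ccccc3)[nH]c2=O)c1` at 2160 nM

Compound 1 stands at 7030 nM and so holds the higher of the two numbers, while compound 2 stands at 2160 nM and lies lower by more than the usual scatter. Compound 3 `COc1cc(/C=C/C(=O)c2cccc(-n3cc(-c4cc(OC)c(OC)c(OC)c4)[nH]c3=O)c2)cc(OC)c1OC` keeps the core of compound 1 and carries 3,4,5-trimethoxyphenyl in place of 4-chlorophenyl on an aromatic carbon. Among the measured compounds shown here, compound 1 and compound 2 differ in more than one place, so no measured step shows what this exchange does. With no measured guide to size or direction, only a small shift toward a lower number is expected. The estimate means a step of a 1.6-fold lower number from compound 1 to compound 3 (0.19 log units; within the scatter) in this assay and nothing beyond the scatter. Compound 3 is estimated at 4500 nM (range 1500 nM to 13000 nM).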

Compound 3, concentration for 50% growth inhibition: 960 nM
Beside the measured number, compound 3's estimate is 4.7-fold (0.67 log units) above it; the whole stated range lies above it.
By their numbers in this assay, from the lowest: compound 3; then compound 2; then compound 1.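

In this assay, the aromatic carbon of the five-membered aromatic ring with 2 nitrogen proves sensitive to the group it carries: exchanging 4-chlorophenyl for 3,4,5-trimethoxyphenyl gives a 7.3-fold lower number from compound 1 to compound 3 (0.86 log units; beyond the scatter). Among the compounds shown here, this is the first step in the set that isolates a single change, and it shows that this position can move growth inhibition with the rest of compound 1 held constant. The exchange removes chlorine and brings in 12 heavy atoms in place of 7, along with 3 hydrogen-bond acceptors in place of 0, but no measurement here links the step to any of these differences. Going by these compounds, it remains open whether all three methoxy groups are needed, or whether a single methoxy group, a hydroxyl or an amine on this phenyl ring would give a similar number. Also unresolved is whether the same exchange would shift the number similarly with a different group on the other side of the enone.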